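The source may hold more compounds than are shown below. What is called first, only, known or untested is meant among the compounds shown, and "the series" means these compounds.

Of the compounds shown here, two sharing one core have been measured in an assay for inhibition of Amine oxidase [flavin-containing] B (Bos taurus), read by fluorescence, with a stated time of 60 min; on this read-out higher numbers stand for weaker inhibition and lower numbers for stronger inhibition. Compound 1 `COc1ccc(/C=N/NC(=O)Cn2c(=O)c(Cc3ccccc3)nc3ccccc32)cc1` gives 82000 nM, and compound 2 `O=C(Cn1c(=O)c(Cc2ccccc2)nc2ccccc21)N/N=C/c1ccc(Br)cc1` gives 26000 nM. For the measured compounds named here, of these two numbers, compound 2 holds the lower one, and the single measured step, a 3.2-fold lower number from compound 1 to compound 2 (0.50 log units; beyond the scatter), came from placing bromo in place of methoxy on an aromatic carbon.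

Compound 3 `O=C(Cn1c(=O)c(Cc2ccccc2)nc2ccccc21)N/N=C1/C(=O)Nc2ccccc21` is not yet measured. It differs from compound 2 by a group of 11 heavy atoms (8 carbon, 2 nitrogen, 1 oxygen; one five-membered non-aromatic ring with 1 hetero atom, one six-membered aromatic ring of carbon only) in place of a group of 9 heavy atoms (7 carbon, 1 nitrogen, 1 bromine; one six-membered aromatic ring of carbon only), on an amide-type nitrogen. Going by the values given here, no measured step bears directly on this change: the step from compound 1 to compound 2 altered only a substituent on the aromatic ring that now leaves entirely, so it shows only that this end of the molecule can move the number modestly. The expected outcome for compound 3 is therefore uncertain, with a step of a 1.9-fold higher number from compound 2 to compound 3 (0.28 log units; within the scatter) expected to stay close to none beyond the scatter, and a wide range. Compound 3 is estimated at 50000 nM, between 8000 nM and 300000 nM.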

Compound 3, half-maximal inhibitory concentration: 96000 nM
Beside the measured number, compound 3's estimate is 1.9-fold (0.28 log units) below it; the measured number falls inside the stated range.
By their numbers in this assay, from the lowest: compound 2; then compounds 1 and 3 (each within the scatter of the next).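

Placing the group with the five-membered non-aromatic ring on the amide-type nitrogen gives a 3.7-fold higher number from compound 2 to compound 3 (0.57 log units; beyond the scatter), so in this assay this larger group loses the advantage held by the bromo compound, and compound 2 remains the lowest of the three. Against the methoxy compound, the same group gives a 1.2-fold higher number from compound 1 to compound 3 (0.07 log units; within the scatter), so compound 1 and compound 3 cannot be told apart, even though the groups they carry at this position differ in their rings and in their hydrogen-bond donor count. No measurement shown here explains these differences.

Going by these compounds, it remains open whether a bromo on the six-membered aromatic ring of the entering group would lower the number. On these data alone, it is also open how a carboxylic acid or an amine in place of the bromo would behave.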